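Compound 4: a Nitrogen Enters the Fused Ring

This account rests on a few compounds, and the source may have more. Where it says the series, first, only, none or still open, it means among the compounds named here.

Compound 1 `O=C(Nc1ccc(-n2ncc3c(F)cccc32)cc1)Nc1ccc(Cl)c(C(F)(F)F)c1` gives 8200 nM in a functional assay on HT-29 cells (Homo sapiens) for cytotoxicity, read by MTT assay, with a stated time of 72 h; a lower number here means a stronger inhibitor, a higher number a weaker inhibitor. Compound 2 `CNc1cccc2c1cnn2-c1ccc(NC(=O)Nc2ccc(Cl)c(C(F)(F)F)c2)cc1` gives 5900 nM. Compound 3 `O=C(Nc1ccc(-n2ncc3c(Cl)cccc32)cc1)Nc1ccc(C(F)(F)F)cc1` gives 1000 nM.

Compound 1 has the highest number of the three, with compound 2 nearest and compound 3 far lower. Compound 4 `O=C(Nc1ccc(-n2ncc3cccnc32)cc1)Nc1ccc(Cl)c(C(F)(F)F)c1` differs from compound 1 in one place: a group of 9 heavy atoms (6 carbon, 3 nitrogen; one five-membered aromatic ring with 2 hetero atoms, one six-membered aromatic ring with 1 hetero atom) in place of a group of 10 heavy atoms (7 carbon, 2 nitrogen, 1 fluorine; one five-membered aromatic ring with 2 hetero atoms, one six-membered aromatic ring of carbon only), on an aromatic carbon. Going by the values given here, the only measured step touching the same fused ring is a 1.4-fold lower number from compound 1 to compound 2 (0.14 log units; within the scatter), where one small group replaced another. Compound 3 differs from compound 1 in two places, so its value cannot be tied to this ring alone. The change in compound 4 alters the ring itself, so the precedent is thin; a step of a 1.3-fold lower number from compound 1 to compound 4 (0.10 log units; within the scatter) is expected, likely none beyond the scatter. Compound 4 is estimated at 6500 nM, between 2500 nM and 17000 nM.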

Compound 4, half-maximal inhibitory concentration: > 32000 nM
Compound 4: a limit, no number; the forecaster's own chance of this, stated with the estimate: 10%; middle value at least 4.9-fold (0.69 log units) from the limit.
By their numbers in this assay, from the lowest: compound 3; then compounds 2 and 1 (each within the scatter of the next). At a limit, above all of these: compound 4.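

Changing the fused ring itself, with a ring nitrogen entering and the fluoro leaving, gives an at least 3.9-fold higher number from compound 1 to compound 4 (0.59 log units; beyond the scatter), whereas replacing only the fluoro gave a 1.4-fold lower number from compound 1 to compound 2 (0.14 log units; within the scatter). In this assay, on these data alone, compound 4 carries a limit of the assay, > 32000 nM, not a number, and the full size of its step stays unknown: the limit of > 32000 nM in this assay, at which 1 of the 4 values shown sits A change to the ring itself can therefore matter more here than a swap of the small group on it.

Compound 4 makes both changes at once, and the compounds shown do not separate them. As far as these compounds go, how a methoxy group or a carboxylic acid in place of the fluoro would read also remains open.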